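Diethylamino Variant of a Chalcone-Type Amine Series

This account rests on a few compounds, and the source may have more. Where it says the series, first, only, none or still open, it means among the compounds named here.

Compound 1 `COC(=O)CN(C)Cc1c(OC)cc(OC)c(C(=O)/C=C/c2ccccc2Cl)c1O` is the strongest of the three measured compounds: in a functional assay on Bel-7402 cells (Homo sapiens) for antiproliferative activity, with a stated time of 72 h (a higher number here means a weaker inhibitor, a lower number a stronger inhibitor), compound 1 gives 8500 nM, and its steps to both others lie beyond the scatter. Compound 2 `COc1cc(OC)c(C(=O)/C=C/c2ccccc2Cl)c(O)c1CN(C)CC(=O)O` gives 35200 nM in this assay, a change of a 4.1-fold higher number from compound 1 to compound 2 (0.62 log units; beyond the scatter). Compound 3 `CCN(C)Cc1c(OC)cc(OC)c(C(=O)/C=C/c2ccccc2Cl)c1O` gives 23300 nM, a change of a 2.7-fold higher number from compound 1 to compound 3 (0.44 log units; beyond the scatter). Between compound 2 and compound 3 the change is a 1.5-fold lower number from compound 2 to compound 3 (0.18 log units; within the scatter).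

Compound 4 `CCN(CC)Cc1c(OC)cc(OC)c(C(=O)/C=C/c2ccccc2Cl)c1O` differs from compound 1 by diethylamino in place of ((methoxycarbonyl)methyl)(methyl)amino on a saturated chain carbon bound to an aromatic carbon. Going by the values given here, the step from compound 1 to compound 3, which replaces methoxycarbonyl with methyl, bears most directly on this change, and it was a modest loss; compound 4 carries that same loss of the methoxycarbonyl group and adds one further carbon on the nitrogen, for which no measured step exists. Compound 4 is therefore expected to land near compound 3, with a step of about a 2.4-fold higher number from compound 1 to compound 4 (0.37 log units; beyond the scatter). The estimate for compound 4 is 20000 nM, within a range from 8000 nM to 50000 nM.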

Compound 4, half-maximal inhibitory concentration: 6700 nM
Compound 4: the middle estimate sits 3.0-fold (0.47 log units) above what was measured, outside the stated range (below it).
By their numbers in this assay, from the lowest: compounds 4 and 1 (each within the scatter of the next); then compounds 3 and 2 (each within the scatter of the next).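

In this assay, the step of a 1.3-fold lower number from compound 1 to compound 4 (0.10 log units; within the scatter) shows that diethylamino in place of ((methoxycarbonyl)methyl)(methyl)amino on this saturated chain carbon bound to an aromatic carbon gives a value within the scatter, so the methoxycarbonyl group is not required for activity at this level. The loss seen when methoxycarbonyl gave way to methyl is recovered by one further methyl on the saturated chain carbon bound to an amine nitrogen, with a 3.5-fold lower number from compound 3 to compound 4 (0.54 log units; beyond the scatter), so a single carbon here carries a step beyond the scatter. The carboxy-bearing amine remains clearly apart, with a 5.3-fold lower number from compound 2 to compound 4 (0.72 log units; beyond the scatter). No measurement shown here explains these steps.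

From the compounds shown here alone, whether a longer chain such as dipropylamino would hold this level remains open. So does whether a cyclic amine such as piperidine or morpholine would do so.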